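A few compounds are considered here, and "the series" means these few. Any claim that something is new, unique, unknown or untested is made for them only; others in the source may bear on it.

Compound 1, `O=C(O)COc1ccc(NC(=O)COc2ccccc2)cc1F`: 29.8%
Compound 2, `CCc1ccc(OCC(=O)Nc2ccc(OCC(=O)O)c(F)c2)cc1`: 14.6%
Compound 3, `CC(C)c1cccc(OCC(=O)Nc2ccc(OCC(=O)O)c(F)c2)c1`: 43.3%

In a functional assay on CHO cells for agonist activity at Free fatty acid receptor 1 (Homo sapiens), read by FLIPR, tested at 100 nM (on this read-out higher numbers stand for a stronger effect at the one concentration tested and lower numbers for a weaker effect), compound 3 stands highest of these three numbers, with a number 13.5 percentage points higher from compound 1 to compound 3 (beyond the scatter) and compound 2 furthest away. Compound 4 is `COc1cccc(OCC(=O)Nc2ccc(OCC(=O)O)c(F)c2)c1`; the change is methoxy in place of isopropyl on an aromatic carbon. Going by the values given here, no measured step swaps isopropyl for methoxy, so the two steps on this aromatic carbon bear only indirectly: a number 15.2 percentage points lower from compound 1 to compound 2 (beyond the scatter) and a number 13.5 percentage points higher from compound 1 to compound 3 (beyond the scatter), which pull in opposite directions and show that a small group at this place can move the number either way. The gain seen with isopropyl is therefore not expected to carry over, and a modest drop, a number 15.3 percentage points lower from compound 3 to compound 4 (beyond the scatter), is expected. Compound 4 is estimated at 28%, between 12% and 45%.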

Compound 4, a percentage reported as activity, at one concentration (the size of the read-out at that concentration, not a potency): 31.7%
Estimate against measurement, compound 4: 3.7 percentage points below; the range from low to high includes it.
By their numbers in this assay, from the lowest: compound 2; then compounds 1 and 4 (each within the scatter of the next); then compound 3.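

In this assay, methoxy on this aromatic carbon cannot be told apart from hydrogen (a number 1.9 percentage points higher from compound 1 to compound 4 (within the scatter)), whereas isopropyl at the same place stays clearly ahead of methoxy (a number 11.6 percentage points lower from compound 3 to compound 4 (beyond the scatter)). So the gain at this place appears with isopropyl but not with methoxy, and 3-methoxyphenyl also reads clearly better than 4-ethylphenyl (a number 17.1 percentage points higher from compound 2 to compound 4 (beyond the scatter)). Nothing available explains these differences.

The compounds shown leave open whether a larger carbon group such as tert-butyl would extend the gain seen with isopropyl. They also leave open how an amine at this place would compare with methoxy.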